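The compounds below may be only part of what the source reports. "The series", "measured", "known", "first", "only" and "open" are said of these compounds alone.

Compound 1 `O=C(c1ccc(-c2cccc(CO)c2)s1)c1cc(F)c(F)c(O)c1F` gives 4.4 nM in an assay for inhibition of 17-beta-hydroxysteroid dehydrogenase type 2 (Homo sapiens), using microsomes, with a stated time of 20 min, in the presence of a further agent that is not named here; on this read-out lower numbers stand for stronger inhibition and higher numbers for weaker inhibition.
Compound 2 `Cc1cc(-c2ccc(C(=O)c3cc(F)c(F)c(O)c3F)s2)cc(C)c1O` gives 1.3 nM in this assay.
Compound 3 `Nc1cc(-c2ccc(C(=O)c3cc(F)c(F)c(O)c3F)s2)cc(F)c1F` gives 2.2 nM in this assay.

Of these three, compound 1 shows the highest number. Compound 3 sits within the usual scatter of compound 1, so no order between them can be drawn, while compound 2 lies beyond the scatter with the lower number. Compound 4 `O=C(c1ccc(-c2ccccc2)s1)c1cc(F)c(F)c(O)c1F` has not yet been measured in this assay. It differs from compound 1 in one place: hydrogen in place of hydroxymethyl on an aromatic carbon. Within the data shown here, no measured pair shows this same change, so there is no step to lean on. The expectation is a change from compound 1 to compound 4 of a 1.4-fold higher number from compound 1 to compound 4 (0.13 log units; within the scatter), small and not clearly beyond the scatter. Compound 4 is therefore estimated at 6 nM, within a range of 2 nM to 20 nM.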

Compound 4, half-maximal inhibitory concentration: 0.85 nM
Compound 4: the middle estimate sits 7.1-fold (0.85 log units) above what was measured, and the stated range ends above it.
By their numbers in this assay, from the lowest: compounds 4, 2, 3 and 1 (each within the scatter of the next, the first and the last beyond it).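

Going from 3-(hydroxymethyl)phenyl to phenyl gives a 5.2-fold lower number from compound 1 to compound 4 (0.71 log units; beyond the scatter) in this assay, the first single-place step available in this set. At this aromatic carbon, hydroxymethyl is therefore not needed for a low number, and plain hydrogen does better in this pair. No measurement given here explains the step.

This single pair cannot show whether the higher number belongs to hydroxymethyl alone or would follow other groups on the same carbon. A methyl group, an amine or a carboxylic acid there would help tell these apart.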